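A few compounds are considered here, and "the series" means these few. Any claim that something is new, unique, unknown or untested is made for them only; others in the source may bear on it.

Working notes on the series, read in a functional assay on K562 cells (Homo sapiens) for cytotoxicity, read by MTT assay, with a stated time of 48 h; a lower number here means a stronger inhibitor, a higher number a weaker inhibitor. Compound 1 `CCOC(=O)/C=C/c1ccc2c(c1)C(=O)C(=O)N2Cc1ccc(OC)cc1` gives 10 nM, compound 2 `CCCCOC(=O)/C=C/c1ccc2c(c1)C(=O)C(=O)N2Cc1ccc(OC)cc1` gives 40 nM and compound 3 `CC(C)(C)OC(=O)/C=C/c1ccc2c(c1)C(=O)C(=O)N2Cc1ccc(Br)cc1` gives 290 nM, so compound 2 holds the second highest of the three numbers. Compound 4 `COc1ccc(CN2C(=O)C(=O)c3cc(/C=C/C(=O)N4CCCC4)ccc32)cc1` departs from compound 2 by pyrrolidin-1-yl in place of butoxy on a carbonyl carbon, with pyrrolidin-1-yl in place of butoxy on a carbonyl carbon. Within the data shown here, no measured compound carries pyrrolidin-1-yl, so no measured step covers this change directly. The nearest guide is the modest change on the butoxy side, a 4.0-fold higher number from compound 1 to compound 2 (0.60 log units; beyond the scatter). A step of similar or somewhat larger size, toward a higher number, is therefore expected, and the estimated step is a 6.3-fold higher number from compound 2 to compound 4 (0.80 log units; beyond the scatter). For compound 4 the estimated value is 250 nM, within an expected range of 50 nM to 1200 nM.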

Compound 4, half-maximal inhibitory concentration: 460 nM
The estimate for compound 4 lay 1.8-fold (0.26 log units) below the measured number, and the stated range covers the measured number.
By their numbers in this assay, from the lowest: compound 1; then compound 2; then compounds 3 and 4 (each within the scatter of the next).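

Among these compounds, on this carbonyl carbon, ester to amide is the largest change so far: pyrrolidin-1-yl in place of butoxy gives a 12-fold higher number from compound 2 to compound 4 (1.06 log units; beyond the scatter), and pyrrolidin-1-yl in place of ethoxy gives a 46-fold higher number from compound 1 to compound 4 (1.66 log units; beyond the scatter), both large steps. Butoxy and pyrrolidin-1-yl have the same heavy-atom count, so that count does not separate compound 2 from compound 4.

From the compounds shown here alone, whether the step follows the amide nitrogen or the ring stays open; diethylamino or piperidin-1-yl on this carbonyl carbon would separate the two. Nothing at hand bears on the cause of these steps.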